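A few compounds are considered here, and "the series" means these few. Any claim that something is new, unique, unknown or untested is made for them only; others in the source may bear on it.

In a functional assay on thoracic aorta (Rattus norvegicus, strain Wistar), with a stated time of 15 min (a lower number here means that less compound is needed, a higher number that more compound is needed for the effect), compound 3 (`COc1ccc(Cl)cc1C(C)NC(=O)NS(=O)(=O)c1ccccc1`) gives > 300000 nM, which is a limit and not a number. Compound 1 (`CCOc1ccc(F)cc1C(C)NC(=O)NS(=O)(=O)c1ccc(C)cc1`) also gives only a limit, > 300000 nM. Together they make up (the limit of > 300000 nM in this assay, at which 2 of the 3 values shown sit). Within the data shown here, compound 2 (`CC(NC(=O)NS(=O)(=O)c1ccc(Cl)cc1)c1cc(Br)ccc1OCc1ccccc1`) is the only one with a number, 57500 nM. Compound 4 (`COc1ccc(Cl)cc1C(C)NC(=O)NS(=O)(=O)c1ccc(Cl)cc1`) follows from compound 3 by chloro in place of hydrogen on an aromatic carbon, phenyl to 4-chlorophenyl. A modest downward move in this assay is expected, and a result still at the limit would fit. This expectation rests on compound 2, which carries the same 4-chlorophenyl group and gives 57500 nM, although it differs elsewhere too. The expected step is an at least 2.0-fold lower number from compound 3 to compound 4 (0.30 log units; that floor lies within the scatter). Compound 4 is estimated at 150000 nM, with an expected range of 40000 nM to 300000 nM.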

Compound 4, half-maximal effective concentration: > 300000 nM
Compound 4 ended at the assay's limit (the forecaster's own chance of this, stated with the estimate: 50%); at least 2.0-fold (0.30 log units) between middle value and limit.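

Compound 3 and compound 4 both stand at a limit in this assay, and the step between them cannot be read. The compounds shown leave open whether 4-chlorophenyl in place of phenyl changes the read-out on this core.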